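Extending Compound 2 at the Ring Nitrogen

The compounds below may be only part of what the source reports. "The series", "measured", "known", "first", "only" and "open" are said of these compounds alone.

Three compounds have been measured in a functional assay on MDA-MB-231 cells (Homo sapiens) for inhibition, read by MTT assay, with a stated time of 48 h; on this read-out lower numbers stand for stronger inhibition and higher numbers for weaker inhibition:
compound 1 `COc1cc(-c2nc3cc(/C=C4\SC(=O)NC4=O)ccc3[nH]2)cc(OC)c1OC` gives 6830 nM;
compound 2 `COc1ccc(-c2nc3cc(/C=C4\SC(=O)NC4=O)ccc3[nH]2)cc1OC` gives 13600 nM;
compound 3 `COc1cc(OC)c(-c2nc3cc(/C=C4\SC(=O)NC4=O)ccc3[nH]2)cc1OC` gives 24500 nM.

Compound 2 is the reference point here. Its number lies within the usual scatter of both neighbours: the step of a 2.0-fold higher number from compound 1 to compound 2 (0.30 log units; within the scatter) and the step of a 1.8-fold higher number from compound 2 to compound 3 (0.26 log units; within the scatter) are each too small to count as a real change, so the three compounds cannot be ranked against one another on this read-out.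

Compound 4 `COc1ccc(-c2nc3cc(/C=C4\SC(=O)N(CC(=O)N5CCOCC5)C4=O)ccc3[nH]2)cc1OC` is the untested member. Compared with compound 2, the change is ((morpholin-4-yl)carbonyl)methyl in place of hydrogen on an amide-type nitrogen in a ring. The shared core and the methoxy pattern of compound 2 are kept; only the ring nitrogen carries something new.

Neither of the measured steps touches this nitrogen. Both concern methoxy groups on the aromatic ring, and both stayed within the scatter. For the measured compounds named here, there is therefore no measured step that bears on the present change, and no basis for expecting movement in this assay in either direction beyond the scatter.

Compound 4 is accordingly expected to give about 13600 nM, with a range from 4000 nM to 45000 nM, which means an expected step of no change at the digits printed from compound 2 to compound 4 (within the scatter).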

Compound 4, half-maximal inhibitory concentration: > 50000 nM
Compound 4: a limit, no number (the forecaster's own chance of this, stated with the estimate: 10%); middle value at least 3.6-fold (0.56 log units) away from the limit.
By their numbers in this assay, from the lowest: compounds 1, 2 and 3 (each within the scatter of the next, the first and the last beyond it). At a limit, above all of these: compound 4.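

The earlier compounds shown here differ only in methoxy groups on the aromatic ring, and their steps stay within the scatter, so they say nothing about the ring nitrogen. In this assay, the change at this amide-type nitrogen gives an at least 3.6-fold higher number from compound 2 to compound 4 (0.56 log units; beyond the scatter), which shows that this position does respond and that replacing the amide hydrogen with ((morpholin-4-yl)carbonyl)methyl weakens inhibition on this read-out. For compound 4, > 50000 nM is a limit of the assay and not a number, so the true size of the step stays unknown: the limit of > 50000 nM in this assay, at which 1 of the 4 values shown sits.

A single group on this nitrogen cannot show whether the loss follows from the morpholine ring, from the carbonyl, or from placing almost anything at this position. A plain methyl, a simple ethyl chain, or an acetic acid side chain ending in a carboxylic acid on the same nitrogen would begin to separate these possibilities, as would a short chain ending in an amine with no carbonyl.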